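A few compounds are considered here, and "the series" means these few. Any claim that something is new, unique, unknown or untested is made for them only; others in the source may bear on it.

Measured so far in a functional assay on MGC-803 cells (Homo sapiens) for antiproliferative activity, read by MTT assay, with a stated time of 48 h; on this read-out lower numbers stand for stronger inhibition and higher numbers for weaker inhibition:
compound 1 `COc1ccc(CN(C(=O)CSc2nc3ccccc3s2)c2cc(OC)c(OC)c(OC)c2)cc1C` gives 6360 nM
compound 2 `COc1ccc(CN(C(=O)CSc2nc3ccccc3s2)c2cc(OC)c(OC)c(OC)c2)cc1N=[N+]=[N-]` gives 187 nM
compound 3 `COc1ccc(CN(C(=O)CSc2nc3ccccc3s2)c2cc(OC)c(OC)c(OC)c2)cc1[N+](=O)[O-]` gives 682 nM

Compound 2 holds the lowest number of the three, with compound 3 nearest to it and compound 1 furthest away. The next question is compound 4 `COc1ccc(CN(C(=O)CSc2nc3ccccc3s2)c2cc(OC)c(OC)c(OC)c2)cc1F`, which keeps the shared core. The change fluoro in place of azido on an aromatic carbon puts fluoro in place of azido on an aromatic carbon, ortho to a methoxy group.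

All three measured steps concern this same carbon. Azido in place of methyl gave the large step (a 34-fold lower number from compound 1 to compound 2 (1.53 log units; beyond the scatter)), and nitro in place of methyl gave a modest one (a 9.3-fold lower number from compound 1 to compound 3 (0.97 log units; beyond the scatter)). Nitro in place of azido gave a modest rise (a 3.6-fold higher number from compound 2 to compound 3 (0.56 log units; beyond the scatter)). Within the data shown here, both other groups tested here give higher numbers than azido, but neither is fluoro, and no measured compound carries fluoro, so the size of this step is poorly fixed. A rise is expected, probably larger than the step to compound 3 and smaller than the gap to compound 1.

The expected step in this assay is a 6.4-fold higher number from compound 2 to compound 4 (0.81 log units; beyond the scatter) and lies beyond the scatter. The estimate for compound 4 is 1200 nM ( expected range 300 nM to 5000 nM).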

Compound 4, half-maximal inhibitory concentration: 416 nM
Beside the measured number, compound 4's estimate is 2.9-fold (0.46 log units) above it; low and high end bracket the measured number.
By their numbers in this assay, from the lowest: compound 2; then compounds 4 and 3 (each within the scatter of the next); then compound 1.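

In this assay, fluoro, with its 1 heavy atom, keeps most of the gain that azido, with 3 heavy atoms, gives at this carbon: a 15-fold lower number from compound 1 to compound 4 (1.18 log units; beyond the scatter) is a large step in its own right, and a 2.2-fold higher number from compound 2 to compound 4 (0.35 log units; beyond the scatter) is only a modest one. Fluoro and nitro cannot be separated at this carbon, as a 1.6-fold lower number from compound 3 to compound 4 (0.21 log units; within the scatter) shows, so azido alone stays at the low end of this assay and methyl alone at the high end, and a group of several heavy atoms is not needed for a large step away from methyl. Nothing shown here gives a measured property of these groups that would account for this order.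

Still open, going by these compounds, is how an amine, a hydroxyl group or a chloro group would compare with fluoro and azido on this same aromatic carbon. Also open, on these data alone, is whether this order holds when the methoxy group ortho to this carbon is replaced by a hydroxyl group or an ethoxy group.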